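This account rests on a few compounds, and the source may have more. Where it says the series, first, only, none or still open, it means among the compounds named here.

Measured so far:
- compound 1 `Clc1ccc(Cn2c(CCc3c[nH]cn3)nnc2Cc2c[nH]c3ccccc23)cc1Cl`: > 10000 nM in an assay on cells for displacement of a labelled ligand from somatostatin receptor type 4 (Homo sapiens), with a stated time of 90 min; a higher number here means a weaker inhibitor, a lower number a stronger inhibitor
- compound 2 `c1ccc(Cn2c(CCc3c[nH]cn3)nnc2Cc2c[nH]c3ccccc23)cc1`: > 10000 nM
- compound 3 `c1ccc(Cn2c(CCc3c[nH]cn3)nnc2CCc2c[nH]c3ccccc23)cc1`: 4470 nM

Compound 1 sits at a limit of this assay, not at a number. The same holds for compound 2; its value is a limit. Among the measured compounds shown here, compound 3 carries the only number among the three, with the other two values being limits (the limit of > 10000 nM in this assay, at which 2 of the 3 values shown sit).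

The step from compound 1 to compound 2 is a step that the two limits leave unreadable from compound 1 to compound 2. The step from compound 2 to compound 3 is an at least 2.2-fold lower number from compound 2 to compound 3 (0.34 log units; beyond the scatter).

Compound 4 `Clc1ccc(Cn2c(CCc3c[nH]cn3)nnc2CCc2c[nH]c3ccccc23)cc1Cl` is compound 3 with 3,4-dichlorophenyl in place of phenyl on a saturated chain carbon bound to an aromatic nitrogen. For the measured compounds named here, the only measured step on the same change is the one from compound 1 to compound 2, which runs in the opposite direction and is a step that the two limits leave unreadable from compound 1 to compound 2: both of its ends are limits, so it gives no readable size and no direction. Going by the values given here, the basis for an expectation is thus thin: compound 3 gives 4470 nM in this assay, and no measured step tells whether the change helps or hurts.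

Compound 4 is therefore expected near the value of compound 3, at an estimated 4500 nM (range 1200 nM to 15000 nM), which means an expected step of a 1.0-fold higher number from compound 3 to compound 4 (0.00 log units; within the scatter) of no clear size in either direction, with a real chance that this assay reports only a limit.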

Compound 4, inhibition constant: 1430 nM
For compound 4 the middle estimate is 3.1-fold (0.50 log units) above the measured one; measured number inside the range.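

In this assay, the change to 3,4-dichlorophenyl on a saturated chain carbon bound to an aromatic nitrogen now has a readable direction and size, with a 3.1-fold lower number from compound 3 to compound 4 (0.49 log units; beyond the scatter); the earlier pair with the same change could not be read. The change from 1H-indol-3-yl to (1H-indol-3-yl)methyl on a saturated chain carbon bound to an aromatic carbon now also appears with the 3,4-dichlorophenyl group in place, with an at least 6.9-fold lower number from compound 1 to compound 4 (0.84 log units; beyond the scatter), which adds a second case to the one seen with phenyl. In both listed cases this change goes the same way, but their sizes cannot be ranked: the same change on two cores in this assay, an at least 2.2-fold lower number (0.34 log units; beyond the scatter) from compound 2 to compound 3 and an at least 6.9-fold lower number (0.84 log units; beyond the scatter) from compound 1 to compound 4; the limit leaves it open whether they differ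

Going by these compounds, whether 3,4-dichlorophenyl also lowers the number when 1H-indol-3-yl is present stays unreadable, and so does any size for that step: the limit of > 10000 nM in this assay, at which 2 of the 4 values shown sit. How a single chlorine on the phenyl, an amine on the benzyl group, or a longer chain carrying the 1H-indol-3-yl group would read in this assay stays open.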